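Cytotoxicity notes: benzyl variation on a shared core

The compounds below may be only part of what the source reports. "The series", "measured", "known", "first", "only" and "open" are said of these compounds alone.

Compound 3 `CCOC(=O)c1cnc(N2CCN(Cc3cccc(C(=O)OC)c3)CC2)nc1Oc1c(C)cc(-c2ccc(C#N)cc2)cc1C` reaches only a limit in an ADME assay on MT4 cells (Homo sapiens) for cytotoxicity, read by MTT assay, with a stated time of 4 days (on this read-out higher numbers stand for lower toxicity in this test and lower numbers for higher toxicity in this test), giving > 125000 nM. Compound 1 `CCOC(=O)c1cnc(N2CCN(Cc3ccc(C#N)cc3)CC2)nc1Oc1c(C)cc(-c2ccc(C#N)cc2)cc1C` likewise stops at a limit, with > 125000 nM. Compound 2 `CCOC(=O)c1cnc(N2CCN(Cc3cccc(F)c3)CC2)nc1Oc1c(C)cc(-c2ccc(C#N)cc2)cc1C` also shows a limit, at > 125000 nM. Among the compounds with values here, the steps a step that the two limits leave unreadable from compound 1 to compound 3 and a step that the two limits leave unreadable from compound 2 to compound 3 therefore have no readable size, and a step that the two limits leave unreadable from compound 1 to compound 2 is no different, since the limit of > 125000 nM in this assay, at which 3 of the 3 values shown sit, holds for every value so far. Compound 4 `CCOC(=O)c1cnc(N2CCN(Cc3ccc(Br)cc3)CC2)nc1Oc1c(C)cc(-c2ccc(C#N)cc2)cc1C` carries the change (4-bromophenyl in place of 3-(methoxycarbonyl)phenyl on a saturated chain carbon bound to an amine nitrogen in a ring). Within the data shown here, no measured step gives a readable size for any change at this position, so a number no higher from compound 3 to compound 4 (the limit leaves the size open) is expected to stay within the scatter, with compound 4 most likely again sitting at the limit. Compound 4 is estimated at 125000 nM, in the range 60000 nM to 250000 nM.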

Compound 4, half-maximal cytotoxic concentration: > 125000 nM
Compound 4: only a limit was reported (the forecaster's own chance of this, stated with the estimate: 85%); the middle value lies on the limit itself.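

No step from compound 1, compound 2 or compound 3 to compound 4 can be read in this assay, since all four stop at the same limit: the limit of > 125000 nM in this assay, at which 4 of the 4 values shown sit.

The compounds shown leave open whether any change at this position alters the cytotoxic concentration at all.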